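A few compounds are considered here, and "the series" means these few. Any claim that something is new, unique, unknown or untested is made for them only; others in the source may bear on it.

Measured so far:
Compound 1 `CN(C(=O)NC(=O)c1ccc(F)c(F)c1)c1nc(C(F)(F)F)c(C(=O)N/N=C/c2ccc(C(F)(F)F)cc2)s1`: in a functional assay on HepG2 cells (Homo sapiens) for inhibition, read by MTT assay, with a stated time of 72 h (on this read-out higher numbers stand for weaker inhibition and lower numbers for stronger inhibition), compound 1 gives 6.26 ug/mL.
Compound 2 `CN(C(=O)NC(=O)c1cccc(C(F)(F)F)c1)c1nc(C(F)(F)F)c(C(=O)N/N=C/c2ccc(C(F)(F)F)cc2)s1`: in this assay compound 2 gives 7.71 ug/mL.
Compound 3 `CN(C(=O)NC(=O)c1ccc(C(F)(F)F)cc1)c1nc(C(F)(F)F)c(C(=O)N/N=C/c2ccc(C(F)(F)F)cc2)s1`: in this assay compound 3 reaches only a limit, > 100 ug/mL, not a number.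

Compound 3 thus stands at the top of the numbers shown, at the limit described by the limit of > 100 ug/mL in this assay, at which 1 of the 3 values shown sits. The steps of an at least 15-fold higher number from compound 1 to compound 3 (1.20 log units; beyond the scatter) and an at least 12-fold higher number from compound 2 to compound 3 (1.11 log units; beyond the scatter) were both large and upward. Compound 4 `CN(C(=O)NC(=O)c1c(F)cccc1F)c1nc(C(F)(F)F)c(C(=O)N/N=C/c2ccc(C(F)(F)F)cc2)s1` differs from compound 3 by 2,6-difluorophenyl in place of 4-(trifluoromethyl)phenyl on a carbonyl carbon. For the measured compounds named here, the two large steps into compound 3 are the ones that bear on this change, read in reverse; a downward step beyond the scatter is therefore expected, an at least 6.6-fold lower number from compound 3 to compound 4 (0.82 log units; beyond the scatter), though no measured compound carries 2,6-difluorophenyl, and compound 1 carries 3,4-difluorophenyl instead. The estimate for compound 4 in this assay is 15 ug/mL, with a range from 4 ug/mL to 60 ug/mL.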

Compound 4, half-maximal inhibitory concentration: 49.6 ug/mL
Estimate against measurement, compound 4: 3.3-fold (0.52 log units) below; the measured number falls inside the stated range.
By their numbers in this assay, from the lowest: compounds 1 and 2 (each within the scatter of the next); then compound 4. At a limit, above all of these: compound 3.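

In this assay, 2,6-difluorophenyl on the carbonyl carbon gives a higher number than the two lowest compounds, with a 7.9-fold higher number from compound 1 to compound 4 (0.90 log units; beyond the scatter) and a 6.4-fold higher number from compound 2 to compound 4 (0.81 log units; beyond the scatter) both beyond the scatter. Two fluorines on this phenyl are therefore not enough in themselves to reach the level of compound 1, so their placement matters among these compounds. From the compounds shown here alone, the step of an at least 2.0-fold lower number from compound 3 to compound 4 (0.30 log units; that floor lies within the scatter) starts from a limit, so its true size remains unknown: the limit of > 100 ug/mL in this assay, at which 1 of the 4 values shown sits.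

Going by these compounds, whether a phenyl carrying a single fluorine, a methoxy group or an amine would return to the lower numbers remains open. The compounds shown also leave the effect of changes elsewhere on the shared core untested.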